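The source may report more compounds than this note shows. Statements on the series, on what has been measured and on what is new or still open speak of the compounds shown alone.

Measured in a functional assay on HGC-27 cells (Homo sapiens) for cytotoxicity, read by MTT assay, with a stated time of 48 h; a lower number here means a stronger inhibitor, a higher number a weaker inhibitor:
Compound 1 `COc1ccc(/C=C/C(=O)/C=C/c2cc3ccccc3nc2Cl)cc1`: > 10000 nM, a limit.
Compound 2 `COc1cc(OC)c(OC)cc1/C=C/C(=O)/C=C/c1cc2ccccc2nc1Cl`: 8730 nM.
Compound 3 `COc1ccc(/C=C/C(=O)/C=C/c2cc3ccccc3nc2Oc2ccccc2)cc1`: > 10000 nM, a limit.

Compound 3 has no number, only the limit > 10000 nM. The series crowds there, with the limit of > 10000 nM in this assay, at which 2 of the 3 values shown sit.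

Compound 4 `COc1ccc(/C=C/C(=O)/C=C/c2cc3ccccc3nc2Oc2ccccc2)cc1OC` adds one change to compound 3: methoxy in place of hydrogen on an aromatic carbon. In words, this is methoxy in place of hydrogen on an aromatic carbon, taking 4-methoxyphenyl to 3,4-dimethoxyphenyl.

For the measured compounds named here, the only measured step, a step that the two limits leave unreadable from compound 1 to compound 3, is a different change and gives no size to carry over. Going by the values given here, the nearest hint is compound 2, the only compound with a number, which gives 8730 nM and carries more methoxy groups than compound 1. That is a single pair with the chloro group kept, so it supports only a weak expectation.

A modest move towards stronger inhibition in this assay is expected, estimated as an at least 1.1-fold lower number from compound 3 to compound 4 (0.04 log units; that floor lies within the scatter), and a second limit would not surprise. For compound 4 the estimated value is 9000 nM, with an expected range of 3000 nM to 20000 nM.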

Compound 4, half-maximal inhibitory concentration: > 10000 nM
Compound 4: a limit, no number; the forecaster's own chance of this, stated with the estimate: 55%; at least 1.1-fold (0.04 log units) between middle value and limit.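

In this assay compound 3 gives > 10000 nM, a limit. Compound 4 gives > 10000 nM, also a limit, so no step can be read between compound 3 and compound 4. The compounds shown leave open whether 3,4-dimethoxyphenyl in place of 4-methoxyphenyl changes cytotoxicity at all with the phenoxy group kept.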